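Trimming the alkyne chain on the sulfonamide aryl ring

The compounds below may be only part of what the source reports. "The series", "measured", "known", "first", "only" and "open" are said of these compounds alone.

Compound 3 `CCCCCCC#Cc1cccc(S(=O)(=O)Nc2cccc(-c3csc(NC(C)=O)n3)c2)c1` carries a hexyl group on the outer triple-bonded carbon of the shared core. In a functional assay on A-375 cells (Homo sapiens) for antiproliferative activity, read by trypan blue exclusion, with a stated time of 48 h, tested at 1 uM (on this read-out lower numbers stand for a stronger effect and higher numbers for a weaker effect at the one concentration tested), compound 3 gives 56.9%. Among the three measured compounds it stands second highest: compound 1 `C#Cc1ccc(S(=O)(=O)Nc2cccc(-c3csc(NC(C)=O)n3)c2)cc1` gives 59.2%, a number within the scatter of compound 3, while compound 2 `CCCCCCCCC#Cc1ccc(S(=O)(=O)Nc2cccc(-c3csc(NC(C)=O)n3)c2)cc1` gives 39.6%, a number that lies beyond the scatter below compound 3.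

Compound 4 `C#Cc1cccc(S(=O)(=O)Nc2cccc(-c3csc(NC(C)=O)n3)c2)c1` differs from compound 3 in one place: hydrogen in place of hexyl on a triple-bonded carbon. Going by the values given here, one measured step bears on this change, and it runs the other way: a number 19.6 percentage points lower from compound 1 to compound 2 (beyond the scatter), a modest downward move when octyl took the place of hydrogen on a triple-bonded carbon. Taking a chain away is therefore expected to push the number upward. Compound 3 already sits close to compound 1, however, so only a small rise is expected. The step from compound 3 to compound 4 is estimated at a number 7.1 percentage points higher from compound 3 to compound 4 (within the scatter), an increase that may stay within the scatter. Compound 4 is expected to give 64%, with a likely range from 50% to 78%.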

Compound 4, a percentage reported as activity, at one concentration (the size of the read-out at that concentration, not a potency): 74.3%
For compound 4 the middle estimate is 10.3 percentage points below the measured one; measured number inside the range.
By their numbers in this assay, from the lowest: compound 2; then compounds 3 and 1 (each within the scatter of the next); then compound 4.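

In this assay, taking the hexyl group off the triple-bonded carbon gives a change beyond the scatter, a number 17.4 percentage points higher from compound 3 to compound 4 (beyond the scatter), so a chain at this place matters with the 3-ethynylphenyl group as well as with the 4-ethynylphenyl group, where the earlier step ran a number 19.6 percentage points lower from compound 1 to compound 2 (beyond the scatter). In both pairs, the compound carrying the chain has the lower number and so the stronger effect at the one concentration tested. The two compounds without a chain also separate, a number 15.1 percentage points higher from compound 1 to compound 4 (beyond the scatter), which shows that swapping 4-ethynylphenyl for 3-ethynylphenyl on the sulfonyl sulfur changes the read-out by itself; no measurement available here explains either change.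

Because hexyl appears only with the 3-ethynylphenyl group and octyl only with the 4-ethynylphenyl group, the compounds shown cannot separate the effect of chain length from that of the ring arrangement. On these data alone, it also remains open how a shorter propyl chain, or a chain ending in an amine or a carboxylic acid, would read at this triple-bonded carbon.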